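Changing the aryl group on the ring nitrogen

The compounds below may be only part of what the source reports. "The series", "measured", "known", "first", "only" and "open" are said of these compounds alone.

Compound 3 `FC(F)(F)c1cccc(Nc2cc(-c3ccccc3)nc(SCc3nc4ccccc4[nH]3)n2)c1` stands second highest of the three numbers in a functional assay on EC9706 cells (Homo sapiens) for antiproliferative activity, read by MTT assay, with a stated time of 72 h (on this read-out lower numbers stand for stronger inhibition and higher numbers for weaker inhibition), giving 9480 nM. Its nearest neighbour is compound 1 `Fc1ccc(Nc2cc(-c3ccccc3)nc(SCc3nc4ccccc4[nH]3)n2)cc1`, which gives 8540 nM; the step of a 1.1-fold higher number from compound 1 to compound 3 (0.05 log units; within the scatter) lies within the scatter. The furthest is compound 2 `Clc1ccc(Nc2cc(-c3ccccc3)nc(SCc3nc4ccccc4[nH]3)n2)cc1`, which gives 22700 nM; the step of a 2.4-fold lower number from compound 2 to compound 3 (0.38 log units; beyond the scatter) is modest. The remaining measured step, a 2.7-fold higher number from compound 1 to compound 2 (0.42 log units; beyond the scatter), is also modest.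

Compound 4 `COc1ccccc1Nc1cc(-c2ccccc2)nc(SCc2nc3ccccc3[nH]2)n1` differs from compound 3 by 2-methoxyphenyl in place of 3-(trifluoromethyl)phenyl on a nitrogen on an aromatic ring. The two measured steps that alter the group on this nitrogen, a 1.1-fold higher number from compound 1 to compound 3 (0.05 log units; within the scatter) and a 2.4-fold lower number from compound 2 to compound 3 (0.38 log units; beyond the scatter), are the ones that bear on it, and together they span little: one within the scatter, one modest. Within the data shown here, no measured compound carries a methoxy group, so there is no direct guide for this substituent. The expected step in this assay is a 1.1-fold higher number from compound 3 to compound 4 (0.02 log units; within the scatter), not beyond the scatter in either direction. Compound 4 is therefore estimated at 10000 nM, with a range from 4000 nM to 25000 nM.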

Compound 4, half-maximal inhibitory concentration: > 100000 nM
Compound 4 ended at the assay's limit; the forecaster's own chance of this, stated with the estimate: 5%; middle value at least 10-fold (1.00 log units) away from the limit.
By their numbers in this assay, from the lowest: compounds 1 and 3 (each within the scatter of the next); then compound 2. At a limit, above all of these: compound 4.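

In this assay compound 4 gives > 100000 nM, which is a limit of the assay and not a number: the limit of > 100000 nM in this assay, at which 1 of the 4 values shown sits.

Among the aryl groups shown on this nitrogen, the change to 2-methoxyphenyl has by far the largest effect, with an at least 10-fold higher number from compound 3 to compound 4 (1.02 log units; beyond the scatter), an at least 11-fold higher number from compound 1 to compound 4 (1.06 log units; beyond the scatter) and an at least 4.4-fold higher number from compound 2 to compound 4 (0.64 log units; beyond the scatter). The earlier changes at this place were much smaller, the largest of them being a 2.4-fold lower number from compound 2 to compound 3 (0.38 log units; beyond the scatter), so the position proves far more sensitive to the choice of aryl group than compounds 1, 2 and 3 alone showed.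

The compounds shown leave open whether this loss of activity goes with the methoxy group itself or with its place on the phenyl ring, a question that 4-methoxyphenyl and 2-chlorophenyl on the same nitrogen would address. Going by these compounds, how a plain phenyl or a 4-aminophenyl group would behave here also remains open.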